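A few compounds are considered here, and "the series" means these few. Any claim that something is new, unique, unknown or untested is made for them only; others in the source may bear on it.

Measured compounds:
Compound 1 `ClCc1cccc(Cn2cnc3c(Cl)ncnc32)c1`: 5490 nM
Compound 2 `ClCc1ccc(Cn2cnc3nc(Cl)nc(Cl)c32)cc1`: 7070 nM
Compound 3 `ClCc1cccc(Cn2cnc3c(Cl)nc(Cl)nc32)c1`: 6160 nM

The three measured compounds were all tested in a functional assay on HCC 2998 cells (Homo sapiens) for cytotoxicity, read by sulforhodamine B assay, with a stated time of 48 h; on this read-out higher numbers stand for lower toxicity in this test and lower numbers for higher toxicity in this test. In this assay compound 1 gives 5490 nM, compound 3 gives 6160 nM and compound 2 gives 7070 nM; the three values lie within the usual scatter of one another. Among the measured compounds shown here, the one single-point change among them is hydrogen in place of chloro on an aromatic carbon, which produces a 1.1-fold lower number from compound 3 to compound 1 (0.05 log units; within the scatter). Compound 2 and compound 3 share the same atoms joined differently, and the difference between the two cores is not broken down here.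

Compound 4 `ClCc1ccc(Cn2cnc3ncnc(Cl)c32)cc1` has not yet been measured in this assay. It differs from compound 2 by hydrogen in place of chloro on an aromatic carbon. This is the same change, at the same kind of place, as that from compound 3 to compound 1. Because that earlier change produced a 1.1-fold lower number from compound 3 to compound 1 (0.05 log units; within the scatter), the step from compound 2 to compound 4 is expected to be of similar size, namely a 1.1-fold lower number from compound 2 to compound 4 (0.04 log units; within the scatter). On this basis compound 4 is estimated to give 6400 nM in this assay, with a likely range from 3200 nM to 12800 nM.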

Compound 4, concentration lethal to 50% of the cells: 5750 nM
Beside the measured number, compound 4's estimate is 1.1-fold (0.05 log units) above it, and the stated range covers the measured number.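

In this assay, hydrogen in place of chloro on the aromatic carbon between two ring nitrogen atoms gives a 1.2-fold lower number from compound 2 to compound 4 (0.09 log units; within the scatter), and set beside the earlier step, the change behaves alike on the two cores: the same change on two cores in this assay, a 1.1-fold lower number (0.05 log units; within the scatter) from compound 3 to compound 1 and a 1.2-fold lower number (0.09 log units; within the scatter) from compound 2 to compound 4, 1.1-fold (0.04 log units) apart, within the scatter of two such steps For this series, the change therefore carries from one core to the other without a detectable difference, and on both cores it leaves the number within the scatter. This does not show that the chloro group has any effect of its own on toxicity in this test, and two cores are too few to say that the same small step would appear on a third.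

The compounds shown carry only hydrogen or chloro at this carbon, so what an amine, a methoxy group or a longer chain would do there remains open. Every compound shown also keeps its chloromethyl group, so what a plain methyl group or a hydroxymethyl group would do in its place is open as well.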